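The source may hold more compounds than are shown below. What is called first, only, known or untested is meant among the compounds shown, and "the series" means these compounds.

In a physicochemical assay for lipophilicity, at pH 7.4 (a higher number here means a more lipophilic compound, a lower number a more polar compound), compound 1 (`Cc1cc(CNCCCC[C@@H](Nc2cc(C)c(F)c(C)c2)C(=O)NO)ccc1F`) gives < 3, which is a limit and not a number. Compound 2 (`Cc1cc(N[C@H](CCCCNCc2cccc(F)c2)C(=O)NO)cc(C)c1F`) gives < 3, also a limit. Compound 3 (`Cc1cc(N[C@H](CCCCNCc2ccc([N+](=O)[O-])cc2)C(=O)NO)cc(C)c1F`) gives < 3, again a limit. Compound 1 therefore stands with the other two at the limit of < 3 in this assay, at which 3 of the 3 values shown sit. Compound 4 (`Cc1cc(N[C@H](CCCCNCc2ccc(C(C)(C)C)cc2)C(=O)NO)cc(C)c1F`) differs from compound 1 in one place: 4-(tert-butyl)phenyl in place of 4-fluoro-3-methylphenyl on a saturated chain carbon bound to an amine nitrogen. Changes at that same place give a step that the two limits leave unreadable from compound 1 to compound 2, a step that the two limits leave unreadable from compound 1 to compound 3 and a step that the two limits leave unreadable from compound 2 to compound 3, so none of them offers a size to carry over. Only a tentative, modest upward move in this assay can be expected, as a step that the limit leaves unreadable from compound 1 to compound 4. For compound 4 the estimated value is 2.8, with an expected range of 2.2 to 3.5.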

Compound 4, distribution coefficient: < 3
Compound 4: only a limit was reported; the forecaster's own chance of this, stated with the estimate: 60%; the middle value does not contradict the limit.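

In this assay, going by these compounds alone, compound 4 gives < 3 as a limit and not a number, so no step to it from compound 1, compound 2 or compound 3 can be read. Where these four compounds actually lie relative to one another stays open, as all of them rest on one shared limit: the limit of < 3 in this assay, at which 4 of the 4 values shown sit.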